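Lengthening the nitrogen substituent from ethyl to isopropyl

The compounds below may be only part of what the source reports. "The series", "measured", "known", "first", "only" and "open" are said of these compounds alone.

Of the compounds shown here, two with a shared core have been measured in an assay on cells for inhibition of Amine oxidase [flavin-containing] B (Homo sapiens), read by fluorescence, with stated times of 30 min and 15 min; a higher number here means a weaker inhibitor, a lower number a stronger inhibitor. Compound 1 `Cn1c(=O)[nH]c2ccc(OCc3ccc(Cl)cc3)cc21` gives 56400 nM in this assay. Compound 2 `CCn1c(=O)[nH]c2ccc(OCCOc3ccc(C(C)C)cc3)cc21` gives 278000 nM, the higher of the two numbers, and its gap to compound 1 lies beyond the usual scatter of the assay.

Compound 3 `CC(C)c1ccc(OCCOc2ccc3[nH]c(=O)n(C(C)C)c3c2)cc1` has not been measured. It differs from compound 2 in one place: methyl in place of hydrogen on a saturated chain carbon bound to an aromatic nitrogen and a saturated chain carbon; cut one bond further out, the same difference reads ethyl to isopropyl. For the measured compounds named here, no measured pair shows a step of this kind, so there is nothing to anchor its size or direction. The expectation is therefore a step of a 1.1-fold lower number from compound 2 to compound 3 (0.05 log units; within the scatter) that stays within the scatter, in either direction. Compound 3 is estimated to give 250000 nM in this assay, with a range from 80000 nM to 800000 nM.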

Compound 3, half-maximal inhibitory concentration: 66700 nM
Beside the measured number, compound 3's estimate is 3.7-fold (0.57 log units) above it; the whole stated range lies above it.
By their numbers in this assay, from the lowest: compounds 1 and 3 (each within the scatter of the next); then compound 2.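

In this assay, the nitrogen substituent proves sensitive to a small change: going from ethyl to isopropyl, a single added methyl on a saturated chain carbon bound to an aromatic nitrogen and a saturated chain carbon, gives a 4.2-fold lower number from compound 2 to compound 3 (0.62 log units; beyond the scatter). For the compounds shown here, this is the only step so far that isolates one place, and it runs toward a stronger inhibitor, although the number for compound 3 still stands at 66700 nM. Nothing available explains the size of this step.

The compounds shown leave open whether the direction holds for a further change on this nitrogen, such as a tert-butyl or cyclopropyl group. With a single step at this position, they also do not show whether the same change would act similarly with the side chain of compound 1.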